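A Methyl Exchanged for Methoxycarbonyl on the Shared Core

A few compounds are considered here, and "the series" means these few. Any claim that something is new, unique, unknown or untested is made for them only; others in the source may bear on it.

Of the compounds shown here, three have been measured so far: compound 1 (`C[C@H]1COC(c2cccc(OC(=O)NC3CCCC3)c2)=N1`), compound 2 (`C[C@H]1COC(c2cccc(OC(=O)NC3CCCCC3)c2)=N1`) and compound 3 (`C[C@@H]1COC(c2cccc(OC(=O)NC3CCCCC3)c2)=N1`). In an assay (strain Wistar) for inhibition of Fatty-acid amide hydrolase 1 (Rattus norvegicus), read by scintillation counting (a higher number here means a weaker inhibitor, a lower number a stronger inhibitor), compound 1 gives 110 nM, compound 2 gives 51 nM and compound 3 gives 16 nM. The first step, a 2.2-fold lower number from compound 1 to compound 2 (0.33 log units; beyond the scatter), was modest. The second, a 3.2-fold lower number from compound 2 to compound 3 (0.50 log units; beyond the scatter), was also modest and rests on (the fact that compounds 2 and 3 differ only in the configuration as drawn). Compound 2 thus holds the second highest of the three numbers, between compound 1 and compound 3.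

Compound 4 (`COC(=O)[C@H]1COC(c2cccc(OC(=O)NC3CCCCC3)c2)=N1`) departs from compound 2 through (methoxycarbonyl in place of methyl on a saturated ring carbon). Among the compounds with values here, no measured step exchanges a group at this saturated ring carbon; the nearest guide is a 3.2-fold lower number from compound 2 to compound 3 (0.50 log units; beyond the scatter), which altered only the drawn configuration at that same carbon and shifted the number modestly. A modest step, in either direction, is therefore expected, and the estimate means a 2.0-fold higher number from compound 2 to compound 4 (0.29 log units; within the scatter). Compound 4 is expected to give about 100 nM, with a range from 30 nM to 400 nM.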

Compound 4, half-maximal inhibitory concentration: 90 nM
The estimate for compound 4 lay 1.1-fold (0.05 log units) above the measured number; the measured number falls inside the stated range.
By their numbers in this assay, from the lowest: compound 3; then compounds 2, 4 and 1 (each within the scatter of the next, the first and the last beyond it).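

In this assay the exchange of methyl for methoxycarbonyl on this saturated ring carbon gives a 1.8-fold higher number from compound 2 to compound 4 (0.25 log units; within the scatter) and so leaves the two compounds indistinguishable. The earlier compounds shown here showed only that the drawn configuration at this carbon matters, whereas compound 4 shows that the group there can go from 1 heavy atom to 4 heavy atoms, with 2 hydrogen-bond acceptors added, without a change that stands clear of the scatter. Nothing measured here bears on why the two numbers sit so close.

Still open, going by these compounds, is whether reversing the drawn configuration would matter with methoxycarbonyl as it does with methyl, where it gives a 3.2-fold lower number from compound 2 to compound 3 (0.50 log units; beyond the scatter) at this same carbon. Also open, on these data alone, is how a carboxylic acid, an amine or an ethyl chain on this carbon would read in this assay when set against these two groups.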